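Swapping the aryl substituent on a ketone-oxazole inhibitor

This account rests on a few compounds, and the source may have more. Where it says the series, first, only, none or still open, it means among the compounds named here.

Measured compounds:
compound 1 `Nc1ccccc1-c1cnc(C(=O)CCCCCCc2ccccc2)o1`: 750 nM
compound 2 `N#Cc1cccc(-c2cnc(C(=O)CCCCCCc3ccccc3)o2)c1`: 15 nM

Of the compounds shown here, two have been measured in an assay (Rattus norvegicus) for inhibition of Fatty-acid amide hydrolase 1 (Homo sapiens); on this read-out lower numbers stand for stronger inhibition and higher numbers for weaker inhibition. Compound 1 gives 750 nM, and compound 2 gives 15 nM. Within the data shown here, compound 2 thus stands at the lowest number of the two, with compound 1 the only neighbour, and the step of a 50-fold lower number from compound 1 to compound 2 (1.70 log units; beyond the scatter) shows how strongly this assay answers to a change of the aryl group on the shared core.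

Compound 3 `O=C(CCCCCCc1ccccc1)c1ncc(-c2ccc(F)cc2)o1` has not yet been measured. It differs from compound 2 as follows: 4-fluorophenyl in place of 3-cyanophenyl on an aromatic carbon. Among the measured compounds shown here, the one measured step that bears on this position is a 50-fold lower number from compound 1 to compound 2 (1.70 log units; beyond the scatter), which was large; it shows that the group at this position matters, but it does not include the 4-fluorophenyl group itself, so the size of the coming step can only be guessed. Since compound 2 holds the lowest number seen, a move toward a higher number is the more likely outcome. Compound 3 is therefore expected to give about 80 nM, between 25 nM and 250 nM, a step of a 5.3-fold higher number from compound 2 to compound 3 (0.73 log units; beyond the scatter).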

Compound 3, inhibition constant: 62 nM
For compound 3 the middle estimate is 1.3-fold (0.11 log units) above the measured one; the range from low to high includes it.
By their numbers in this assay, from the lowest: compound 2; then compound 3; then compound 1.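

In this assay, the position on the aromatic carbon next to the ring oxygen proves not to depend on the 3-cyanophenyl group alone for a low number: the 4-fluorophenyl group, which has no nitrile, also gives a far lower number than the 2-aminophenyl group (a 12-fold lower number from compound 1 to compound 3 (1.08 log units; beyond the scatter)). The two low-number groups are still told apart, though more narrowly, and the 3-cyanophenyl group keeps the lower number (a 4.1-fold higher number from compound 2 to compound 3 (0.62 log units; beyond the scatter)). That modest step changes the substituent and its place on the phenyl ring together, so the three compounds now give an order, with the 2-aminophenyl group highest, but they do not show how much of that step belongs to the nitrile or the fluorine and how much to the place each occupies.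

A 4-cyanophenyl, a 3-fluorophenyl or a plain phenyl group at this position would be needed to separate those two changes, and a 3-aminophenyl group would show whether the amine or its place goes with the high number of compound 1. Nothing at hand gives a reason for any of these differences.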